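This account rests on a few compounds, and the source may have more. Where it says the series, first, only, none or still open, it means among the compounds named here.

The series keeps one shared core, carrying a fluorophenyl on a sulfonyl sulfur and a methoxyphenyl, and is followed in an ADME assay on microsomes from liver (Homo sapiens) for metabolic stability, tested at 2.5 uM; a lower number here means slower removal, a higher number faster removal of the compound. Compound 1 `COc1ccc(-c2c(S(=O)(=O)c3cc(F)cc(F)c3)cnc3c(F)cccc23)cc1` gives 2.59 mL/min. Compound 2 `COc1ccc(-c2c(S(=O)(=O)c3ccc(F)cc3)cnc3c(F)cccc23)cc1` gives 2.41 mL/min. Compound 3 `COc1ccc(-c2c(S(=O)(=O)c3cccc(F)c3)cnc3c(F)cccc23)cc1` gives 2.48 mL/min. Compound 1 holds the largest of the three numbers, yet the steps of a 1.1-fold lower number from compound 1 to compound 2 (0.03 log units; within the scatter) and a 1.0-fold lower number from compound 1 to compound 3 (0.02 log units; within the scatter) both fall within the scatter, as does a 1.0-fold higher number from compound 2 to compound 3 (0.01 log units; within the scatter). Compound 4 `COc1cccc(-c2c(S(=O)(=O)c3cc(F)cc(F)c3)cnc3c(F)cccc23)c1` differs from compound 1 by 3-methoxyphenyl in place of 4-methoxyphenyl on an aromatic carbon. Going by the values given here, no measured step touches the methoxyphenyl: the three known steps all alter the fluorophenyl on the sulfonyl sulfur, and none leaves the scatter. The step of a 1.0-fold higher number from compound 1 to compound 4 (0.00 log units; within the scatter) is therefore expected to remain within the scatter. For compound 4 the estimate in this assay is 2.6 mL/min, between 1.4 mL/min and 4.8 mL/min.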

Compound 4, intrinsic clearance in a liver preparation (reported as CLH), per the amount of preparation that the assay uses: 2.76 mL/min
For compound 4 the middle estimate is 1.1-fold (0.03 log units) below the measured one; the measured number falls inside the stated range.
By their numbers in this assay, from the lowest: compounds 2, 3, 1 and 4 (each within the scatter of the next).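

Swapping 4-methoxyphenyl for 3-methoxyphenyl on an aromatic carbon gives a 1.1-fold higher number from compound 1 to compound 4 (0.03 log units; within the scatter) in this assay. Going by these compounds alone, this is the first reading at the methoxyphenyl, and it shows that the site of the methoxy group on that ring, like the fluoro pattern on the sulfonyl-bound phenyl, leaves the number within the scatter for these compounds. Nothing available bears on the reason for this result. Open, from the compounds shown here alone, is whether replacing the methoxy group with an amine or a carboxylic acid would also stay within the scatter. Also open, going by these compounds, is whether 3-methoxyphenyl behaves alike when paired with 4-fluorophenyl or 3-fluorophenyl on the sulfonyl sulfur.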